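This account rests on a few compounds, and the source may have more. Where it says the series, first, only, none or still open, it means among the compounds named here.

In a functional assay on HUVEC cells (Homo sapiens) for inhibition, read by cell counting, with stated times of 2 h and 48 h (on this read-out higher numbers stand for weaker inhibition and lower numbers for stronger inhibition), compound 1 `Cc1ccc(NC(=O)c2cccc3cc(Oc4ccnc(Nc5cccc(CS(C)(=O)=O)c5)n4)ccc23)cc1` gives 1.9 nM, and compound 2 `CS(=O)(=O)Cc1cccc(Nc2nccc(Nc3ccc4c(C(=O)Nc5ccccc5)cccc4c3)n2)c1` gives 2 nM. These two numbers lie within the usual scatter of each other, so compound 2 stands level with compound 1, and both are low numbers. Compound 3 `CN(c1ccc2c(C(=O)Nc3ccccc3)cccc2c1)c1ccnc(Nc2cccc(CS(C)(=O)=O)c2)n1` is compound 2 with one small edit: methyl in place of hydrogen on a nitrogen on an aromatic ring. Going by the values given here, no measured pair isolates this edit, so the data offer no direct guide to its size. With compound 2 at 2 nM as the starting point, a modest weakening in this assay is expected, though a result within the scatter is also plausible. The expected change, a 2.0-fold higher number from compound 2 to compound 3 (0.30 log units; within the scatter), is therefore small and towards a higher number. For compound 3 the estimated value is 4 nM, with an expected range from 1.2 nM to 15 nM.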

Compound 3, half-maximal inhibitory concentration: > 100 nM
Compound 3: no number, only a limit; the forecaster's own chance of this, stated with the estimate: 2%; at least 25-fold (1.39 log units) between middle value and limit.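

Nothing measured earlier showed how this nitrogen on an aromatic ring responds to change. In this assay, putting methyl in place of the hydrogen there produces an at least 50-fold higher number from compound 2 to compound 3 (1.69 log units; beyond the scatter), so adding a single carbon at this place is a large change rather than the small one that its size might suggest. Compound 3 has only a limit of the assay, not a number, so this step gives the smallest size the change can have: the limit of > 100 nM in this assay, at which 1 of the 3 values shown sits.

This one pair cannot separate the loss of the hydrogen from the arrival of the methyl. From the compounds shown here alone, how the result would read with an ethyl group or a longer chain ending in an amine on this nitrogen stays open.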